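Working notes: chloro to fluoro step from compound 1

A few compounds are considered here, and "the series" means these few. Any claim that something is new, unique, unknown or untested is made for them only; others in the source may bear on it.

Measured so far:
- compound 1 `C#CCNC1CCc2c(SCc3cccc(Cl)c3)cccc21`: 1090 nM
- compound 2 `C#CCNC1CCc2c(SCCc3cccc(Cl)c3)cccc21`: "not determined" (no result reported)
- compound 3 `C#CCNC1CCc2c(SCCc3ccc(C(F)(F)F)cc3)cccc21`: 8780 nM

In an ADME assay on isolated protein for inhibition of Amine oxidase [flavin-containing] B (Homo sapiens) (on this read-out higher numbers stand for weaker inhibition and lower numbers for stronger inhibition), compound 1 gives 1090 nM, the lowest of the two numbers available in the series. Within the data shown here, compound 3 gives 8780 nM in this assay, a number higher than that of compound 1 by a margin beyond the scatter; compound 3 differs from compound 1 in more than one place, so no single step is read from the pair. In this assay compound 2 is reported as "not determined" (no result reported), and nothing about it enters the comparison.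

Compound 4 `C#CCNC1CCc2c(SCc3cccc(F)c3)cccc21` is the next compound to be tested. It differs from compound 1 as follows: fluoro in place of chloro on an aromatic carbon. Among the measured compounds shown here, no step between measured compounds covers this change, so the expectation rests on compound 1 alone. The step of a 1.8-fold higher number from compound 1 to compound 4 (0.26 log units; within the scatter) is estimated to be small and toward a higher number, at about the edge of the scatter. Compound 4 is therefore expected to give 2000 nM in this assay, within a range from 700 nM to 6000 nM.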

Compound 4, half-maximal inhibitory concentration: 11600 nM
Beside the measured number, compound 4's estimate is 5.8-fold (0.76 log units) below it; the measured number lies above the stated range.
By their numbers in this assay, from the lowest: compound 1; then compounds 3 and 4 (each within the scatter of the next).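

Working notes on the halogen at this position: in this assay, fluoro in place of chloro on the aromatic carbon gives an 11-fold higher number from compound 1 to compound 4 (1.03 log units; beyond the scatter), the first step in the series that can be read at a single place. The change from 3-chlorophenyl to 3-fluorophenyl exchanges one heavy atom for one heavy atom, with no change in ring, charge or count of hydrogen-bond donors and acceptors, and this position still separates the two compounds by a margin well beyond the scatter, so chloro is clearly favoured over fluoro in this pair. The data shown give no measurement that accounts for the size of this step.

As far as these compounds go, with a single pair, it remains open whether the trend continues with bromo or iodo at this position, or how methyl, methoxy, nitrile or plain hydrogen on the same aromatic carbon would compare with chloro. Also open, from the compounds shown here alone, is whether the chloro to fluoro step keeps its size when a longer chain carries the aromatic ring, or when the group sits elsewhere on that ring.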